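Swapping Isopropoxy for Methylsulfanyl at One Ring Position

The source may hold more compounds than are shown below. What is called first, only, known or untested is meant among the compounds shown, and "the series" means these compounds.

In a functional assay on HL-60 cells (Homo sapiens) for antiproliferative activity, read by MTT assay, with a stated time of 72 h (on this read-out lower numbers stand for stronger inhibition and higher numbers for weaker inhibition), compound 1 (`COc1ccc(-c2ncnn2-c2cc(OC)c(OC)c(OC)c2)cc1`) gives 120 nM. Within the data shown here, compound 2 (`COc1cc(-n2ncnc2-c2ccc(OC(C)C)cc2)cc(OC)c1OC`) gives 700 nM, the higher of the two numbers so far, which makes it the weaker inhibitor of the pair. Among the measured compounds shown here, the only measured step, a 5.8-fold higher number from compound 1 to compound 2 (0.77 log units; beyond the scatter), is a modest one that came with isopropyl replacing methyl on an oxygen on an aromatic ring.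

Compound 3 (`COc1cc(-n2ncnc2-c2ccc(SC)cc2)cc(OC)c1OC`) is still unmeasured. Its change from compound 2 is methylsulfanyl in place of isopropoxy on an aromatic carbon. The new group ends in a methyl, as does the group in compound 1 at 120 nM, so part of the earlier loss may be recovered. For the measured compounds named here, no measured step here tests oxygen against sulfur, which limits confidence. The expected change in this assay is modest and towards a lower number, a 3.2-fold lower number from compound 2 to compound 3 (0.50 log units; beyond the scatter). For compound 3 the estimate is 220 nM, with an expected range of 50 nM to 900 nM.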

Compound 3, half-maximal inhibitory concentration: 500 nM
For compound 3 the middle estimate is 2.3-fold (0.36 log units) below the measured one, within the range that was stated.
By their numbers in this assay, from the lowest: compound 1; then compounds 3 and 2 (each within the scatter of the next).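

In this assay, methylsulfanyl in place of isopropoxy gives a 1.4-fold lower number from compound 2 to compound 3 (0.15 log units; within the scatter) and so cannot be told apart from isopropoxy at this position, even though the entering group has 2 heavy atoms and the leaving group has 4. Compared with methoxy, the same group gives a 4.2-fold higher number from compound 1 to compound 3 (0.62 log units; beyond the scatter) and shows that a group ending in a methyl does not by that alone restore the number of compound 1, as exchanging oxygen for sulfur in methoxy brings a modest rise. No supporting measurement is available to explain either step.

The compounds shown leave open how ethoxy, a bare methyl or an amine would read at this position. They also leave open whether any group on this ring carbon can match methoxy or give a lower number.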